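This account rests on a few compounds, and the source may have more. Where it says the series, first, only, none or still open, it means among the compounds named here.

Working notes on the series. Compound 1 `Cc1c(O)c(=O)ccn1CCCCNc1ccnc2cc(Cl)ccc12` and compound 3 `COc1c(C)n(CCCCNc2ccnc3cc(Cl)ccc23)ccc1=O` share a core and differ in one place: methyl in place of hydrogen on an oxygen on an aromatic ring. In an ADME assay on KB cells (Homo sapiens) for cytotoxicity, read by resazurin assay, with a stated time of 72 h (a higher number here means a weaker inhibitor, a lower number a stronger inhibitor), compound 1 gives 185000 nM, and compound 3 gives 27000 nM; the step between them is a 6.9-fold lower number from compound 1 to compound 3 (0.84 log units; beyond the scatter). Compound 2 `Cc1c(O)c(=O)ccn1CCCCCCNc1ccnc2cc(Cl)ccc12` differs from compound 1 in more than one place, and the difference between the two cores is not broken down here. In this assay compound 2 gives 4000 nM, the lowest of the three numbers, standing beyond the scatter from both compound 3 and compound 1. Compound 4 `COc1c(C)n(CCCCCCNc2ccnc3cc(Cl)ccc23)ccc1=O` is not yet measured. Its change from compound 2 is methyl in place of hydrogen on an oxygen on an aromatic ring, the same change as from compound 1 to compound 3, made at the same place. Within the data shown here, the expected step from compound 2 to compound 4 in this assay is a 4.0-fold lower number from compound 2 to compound 4 (0.60 log units; beyond the scatter), which rests on the earlier step of a 6.9-fold lower number from compound 1 to compound 3 (0.84 log units; beyond the scatter) in compounds 1 and 3 and is taken somewhat smaller because only that one pair a 6.9-fold lower number from compound 1 to compound 3 (0.84 log units; beyond the scatter) supports it. Compound 4 is thus expected near 1000 nM, with a range from 300 nM to 4000 nM.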

Compound 4, half-maximal inhibitory concentration: 47000 nM
The estimate for compound 4 lay 47-fold (1.67 log units) below the measured number; the measured number lies above the stated range.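

In this assay the change from hydroxy to methoxy gives a 12-fold higher number from compound 2 to compound 4 (1.07 log units; beyond the scatter), which runs opposite in direction to the step seen on the core of compound 1. The two steps do not agree, so in this series the change cannot be carried from one core to the other as a fixed shift: the same change on two cores in this assay, a 6.9-fold lower number (0.84 log units; beyond the scatter) from compound 1 to compound 3 and a 12-fold higher number (1.07 log units; beyond the scatter) from compound 2 to compound 4, 81-fold (1.91 log units) apart, beyond the scatter of two such steps The result rests on a single pair on each core; it shows that the step differs between these two cores, but not which feature of the cores sets the steps apart or how the change would run on a third core.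

Among these compounds, still open is how the same change behaves with a longer chain in place of the one in compound 2, and whether the step then follows the pair of compound 1 and compound 3 or that of compound 2 and compound 4. Also open, on these data alone, is whether ethoxy or an amine in place of the methoxy would follow either pair.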